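The source may hold more compounds than are shown below. What is called first, only, known or untested is meant among the compounds shown, and "the series" means these compounds.

The series shares a fused core carrying a fluorophenyl group; compound 1 `COc1ccc2[nH]c(-c3ccccc3F)cc(=O)c2c1OC` and compound 2 `COc1ccc2[nH]c(-c3cccc(F)c3)cc(=O)c2c1OC` have one core, compound 3 `COc1cc2c(=O)cc(-c3ccccc3F)[nH]c2cc1O` and compound 4 `COc1cc2c(=O)cc(-c3cccc(F)c3)[nH]c2cc1O` another, and the difference between the two cores is not broken down here. In a functional assay on HL-60 cells (Homo sapiens) for cytotoxicity, read by MTT assay, with a stated time of 48 h (a higher number here means a weaker inhibitor, a lower number a stronger inhibitor), compound 1 gives 3700 nM. The change 3-fluorophenyl in place of 2-fluorophenyl on an aromatic carbon produces a 2.8-fold lower number from compound 1 to compound 2 (0.45 log units; beyond the scatter). In this assay compound 2 gives 1300 nM, and compound 3 gives 1300 nM, level with compound 2 at the digits printed and therefore not ordered against it. Compound 4 differs from compound 3 by 3-fluorophenyl in place of 2-fluorophenyl on an aromatic carbon, the same change that separates compound 1 from compound 2. Whether that change carries over to the second core rests on a single measured pair, so the expectation is held loosely. Among the measured compounds shown here, the estimated step is a 2.2-fold lower number from compound 3 to compound 4 (0.34 log units; beyond the scatter), expected to resemble the earlier one because a 2.8-fold lower number from compound 1 to compound 2 (0.45 log units; beyond the scatter) is the only guide available. On that basis compound 4 is estimated in this assay at 600 nM, with a likely range from 250 nM to 1500 nM.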

Compound 4, half-maximal inhibitory concentration: 900 nM
The estimate for compound 4 lay 1.5-fold (0.18 log units) below the measured number; low and high end bracket the measured number.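

On the core of compound 3, placing 3-fluorophenyl where 2-fluorophenyl stood gives, in this assay, a 1.4-fold lower number from compound 3 to compound 4 (0.16 log units; within the scatter), so this pair is not separated by the measurement. Set beside the step on the core of compound 1, the change cannot be said to behave differently on the two cores: the same change on two cores in this assay, a 2.8-fold lower number (0.45 log units; beyond the scatter) from compound 1 to compound 2 and a 1.4-fold lower number (0.16 log units; within the scatter) from compound 3 to compound 4, 2.0-fold (0.29 log units) apart, within the scatter of two such steps. Among the compounds shown here, this is consistent with the change carrying over from one core to the other, but it does not establish a shared step of one size, as the evidence is two pairs in a single assay, and only the step on the core of compound 1 lies beyond the scatter.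

The compounds shown leave open whether a group other than fluorine on the phenyl ring, such as chlorine, a methoxy group or an amine, would give a step of its own on either core. They also leave open how the change would fare on a third core, and how the two cores compare when everything else is held equal.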